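Bromo in Place of Ethoxy: What to Expect for Compound 3

The source may hold more compounds than are shown below. What is called first, only, known or untested is meant among the compounds shown, and "the series" means these compounds.

Compound 1 `COc1ccc(C(=O)/C=C/c2ccc(Cl)c(Cl)c2)c2c1C=CC(C)(C)O2` gives 9030 nM in a functional assay on K562 cells (Homo sapiens) for antiproliferative activity, read by MTT assay, with a stated time of 24 h; a higher number here means a weaker inhibitor, a lower number a stronger inhibitor.
Compound 2 `CCOc1cc(/C=C/C(=O)c2ccc(OC)c3c2OC(C)(C)C=C3)ccc1O` gives > 10000 nM in this assay.

Compound 2 stands at the limit of > 10000 nM in this assay, at which 1 of the 2 values shown sits: its result is a limit of the assay, not a number. Compound 3 `COc1ccc(C(=O)/C=C/c2ccc(O)c(Br)c2)c2c1C=CC(C)(C)O2` differs from compound 2 by bromo in place of ethoxy on an aromatic carbon, ortho to a hydroxy group and meta to a large group. Among the measured compounds shown here, no measured pair shares this change, so the expectation rests on the two values alone. Compound 1, which carries two chloro groups and no hydroxy group, gives 9030 nM, a weak but real number. The expected step of an at least 1.1-fold lower number from compound 2 to compound 3 (0.04 log units; that floor lies within the scatter) is therefore small and toward a stronger inhibitor, if beyond the scatter at all. Compound 3 is estimated at 9000 nM in this assay, with a range from 3000 nM to 30000 nM.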

Compound 3, half-maximal inhibitory concentration: > 10000 nM
Compound 3 was reported as a limit; the forecaster's own chance of this, stated with the estimate: 45%; at least 1.1-fold (0.04 log units) between middle value and limit.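

Putting bromo in place of ethoxy at this position, ortho to a hydroxy group, still leaves compound 3 at a limit of the assay and not at a number: the limit of > 10000 nM in this assay, at which 2 of the 3 values shown sit.

The steps between two limits cannot be read, so bromo and ethoxy cannot be ranked against each other here. Putting 3-bromo-4-hydroxyphenyl in place of 3,4-dichlorophenyl gives an at least 1.1-fold higher number from compound 1 to compound 3 (0.04 log units; that floor lies within the scatter), so this pair does not establish a real difference either.

Still open, going by these compounds, is whether an amine or a carboxylic acid in place of the bromo would give a measurable number in this assay. Also open is what the hydroxy group contributes, as no pair shown differs in that group alone.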